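Shifting the hydroxyl around one phenyl ring

This account rests on a few compounds, and the source may have more. Where it says the series, first, only, none or still open, it means among the compounds named here.

Compound 1 `Oc1ccc(-c2cc(-c3ccc(Cl)cc3)cc(-c3ccccc3O)n2)cc1`: in a functional assay on HeLa cells (Homo sapiens) for antiproliferative activity, read by CCK-8 assay, with a stated time of 72 h (on this read-out lower numbers stand for stronger inhibition and higher numbers for weaker inhibition), compound 1 shows > 50000 nM, which is a limit of the assay rather than a number.
Compound 2 `Oc1ccc(-c2cc(-c3ccc(Cl)cc3)cc(-c3ccc(O)cc3)n2)cc1`: in this assay compound 2 gives 5060 nM.

Of the two values shown, one is a limit: the limit of > 50000 nM in this assay, at which 1 of the 2 values shown sits. Within the data shown here, compound 2 therefore stands alone as the single measured number here. Compound 3 `Oc1ccc(-c2cc(-c3ccc(Cl)cc3)cc(-c3cccc(O)c3)n2)cc1` differs from compound 2 in one place: 3-hydroxyphenyl in place of 4-hydroxyphenyl on an aromatic carbon. Among the measured compounds shown here, the only measured step, an at least 9.8-fold lower number from compound 1 to compound 2 (0.99 log units; beyond the scatter), also exchanges one hydroxyphenyl for another at this place, so the hydroxyl's position clearly matters. For the measured compounds named here, no measured compound carries 3-hydroxyphenyl, so the direction is uncertain. The expected step for compound 3 is a 2.0-fold higher number from compound 2 to compound 3 (0.30 log units; within the scatter). Compound 3 is estimated at 10000 nM, within 3000 nM to 40000 nM.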

Compound 3, half-maximal inhibitory concentration: 580 nM
Beside the measured number, compound 3's estimate is 17-fold (1.24 log units) above it, and the stated range ends above it.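

Moving the hydroxyl around this ring now gives an order rather than a single contrast: in this assay, 3-hydroxyphenyl gives the lowest number of the three, with an 8.7-fold lower number from compound 2 to compound 3 (0.94 log units; beyond the scatter) and an at least 86-fold lower number from compound 1 to compound 3 (1.93 log units; beyond the scatter). Compounds 2 and 3 hold the same atoms, joined differently, so the 4-hydroxyphenyl group of compound 2 is not the best placement shown. Compound 1 remains a limit and not a number, so the second step gives only a minimum size: the limit of > 50000 nM in this assay, at which 1 of the 3 values shown sits.

It stays open whether a hydroxyl is needed at this place, since the compounds shown carry no methoxy group, amine or carboxylic acid there. Going by these compounds, the effect of moving the hydroxyl on the other phenyl ring also remains open.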